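Sulfonylpiperazine in place of piperidine at the chain end

The source may hold more compounds than are shown below. What is called first, only, known or untested is meant among the compounds shown, and "the series" means these compounds.

Compound 1 `COc1cc(N)c(Cl)cc1C(=O)NC1CCN(CCCCCCCCS(=O)(=O)O)CC1`: in a functional assay on HEK293 cells for activation of 5-hydroxytryptamine receptor 4 (Homo sapiens), read by cAMP accumulation (a higher number here means a larger maximal response, a lower number a smaller maximal response), compound 1 reaches > 100%, which is a limit of the assay and not a number.
Compound 2 `COc1cc(N)c(Cl)cc1C(=O)NC1CCN(CCCCCN2CCCCC2)CC1`: in this assay compound 2 reaches > 100%, again a limit rather than a number.

Within the data shown here, compound 2 thus stands at the limit, and the one measured step, a step that the two limits leave unreadable from compound 1 to compound 2, cannot be read in size or direction. Compound 3 `COc1cc(N)c(Cl)cc1C(=O)NC1CCN(CCCCCN2CCN(S(C)(=O)=O)CC2)CC1` differs from compound 2 by 4-(methylsulfonyl)piperazin-1-yl in place of piperidin-1-yl on a saturated chain carbon, five bonds along the chain from an amine nitrogen in a ring. Among the measured compounds shown here, no measured step bears on this change; the only evidence is the limit of > 100% in this assay, at which 2 of the 2 values shown sit, which offers no direction. Because the limit of > 100% in this assay, at which 2 of the 2 values shown sit, places every value shown at the limit, compound 3 is expected to give a maximal response near the full reference level, with the step of a number no higher from compound 2 to compound 3 (the limit leaves the size open) estimated as none beyond the scatter. Compound 3 is therefore estimated at 100% in this assay, within the range 85% to 110%.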

Compound 3, intrinsic activity: the largest response reached, in percent of the reference agonist's: > 100%
Compound 3 was reported as a limit (the forecaster's own chance of this, stated with the estimate: 55%); the middle value lies on the limit itself.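

In this assay compound 3 gives > 100%, which is a limit of the assay and not a number. The steps among compound 1, compound 2 and compound 3 cannot be read in size or direction. The compounds shown leave open whether their maximal responses differ at all.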